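Propyl in Place of Hydrogen on a Saturated Ring Carbon

A few compounds are considered here, and "the series" means these few. Any claim that something is new, unique, unknown or untested is made for them only; others in the source may bear on it.

In a functional assay on HOS cells (Homo sapiens) for antiproliferative activity, read by sulforhodamine B assay (a higher number here means a weaker inhibitor of growth, a lower number a stronger inhibitor of growth), compound 2 `O[C@H]1CO[C@H](COCc2ccccc2)[C@@H](OCc2ccccc2)[C@@H]1OCc1ccccc1` gives 37900 nM, and compound 1 `c1ccc(COC[C@H]2OCC[C@@H](OCc3ccccc3)[C@@H]2OCc2ccccc2)cc1` gives 22200 nM; the step of a 1.7-fold higher number from compound 1 to compound 2 (0.23 log units; within the scatter), so the two stand together within the scatter. Compound 3 `CCC[C@@H]1O[C@H](COCc2ccccc2)[C@@H](OCc2ccccc2)[C@H](OCc2ccccc2)[C@H]1O` differs from compound 2 by propyl in place of hydrogen on a saturated ring carbon. Among the compounds with values here, no measured step introduces a propyl, and the only step recorded, hydroxy in place of hydrogen, stayed within the scatter, so no change beyond the scatter is expected, in either direction. Compound 3 is therefore expected to give about 35000 nM, between 12000 nM and 100000 nM. The expected step is a 1.1-fold lower number from compound 2 to compound 3 (0.03 log units; within the scatter).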

Compound 3, concentration for 50% growth inhibition: 38600 nM
Beside the measured number, compound 3's estimate is 1.1-fold (0.04 log units) below it; the range from low to high includes it.
By their numbers in this assay, from the lowest: compounds 1, 2 and 3 (each within the scatter of the next).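

In this assay, propyl in place of hydrogen on the saturated ring carbon next to the ring oxygen gives a 1.0-fold higher number from compound 2 to compound 3 (0.01 log units; within the scatter), the first step shown at this position. Compound 2 and compound 3 therefore stand together, and at this carbon propyl is tolerated in this read-out of growth inhibition. Nothing available explains this result.

Going by these compounds, whether an amine, a carboxylic acid or a longer chain on this same carbon would also stand with them remains open. So does whether propyl would give the same reading without the hydroxy group on the ring.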